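The source may hold more compounds than are shown below. What is called first, only, known or untested is meant among the compounds shown, and "the series" means these compounds.

The measured compounds in a functional assay on HepG2 cells (Homo sapiens) for inhibition, read by MTT assay, with a stated time of 72 h; a higher number here means a weaker inhibitor, a lower number a stronger inhibitor:

Compound 1 `CC(C)(C)n1cc2c(n1)C(=O)CC1(CCN(C(=O)c3cc(-c4ccccc4)nc4ccccc34)CC1)O2`: compound 1 gives 2110 nM.
Compound 2 `CC(C)(C)n1cc2c(n1)C(=O)CC1(CCN(C(=O)c3cc(-c4ccc(N)cc4)nc4ccccc34)CC1)O2`: compound 2 gives 630 nM.
Compound 3 `CCOc1cc(C(=O)N2CCC3(CC2)CC(=O)c2nn(C(C)(C)C)cc2O3)c2ccccc2n1`: for compound 3 the result is a limit of the assay, > 10000 nM.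

Among the two plain numbers, compound 1 stands highest, and the nearest is compound 2, with a 3.3-fold lower number from compound 1 to compound 2 (0.52 log units; beyond the scatter). Compound 3 sits at the limit described by the limit of > 10000 nM in this assay, at which 1 of the 3 values shown sits.

Compound 4 `CC(C)Oc1cc(C(=O)N2CCC3(CC2)CC(=O)c2nn(C(C)(C)C)cc2O3)c2ccccc2n1` differs from compound 1 in one place: isopropoxy in place of phenyl on an aromatic carbon.

Among the compounds with values here, two measured steps bear on this change. From compound 1 to compound 3 the ethoxy in place of phenyl gave an at least 4.7-fold higher number from compound 1 to compound 3 (0.67 log units; beyond the scatter), and from compound 2 to compound 3 the ethoxy in place of 4-aminophenyl gave an at least 15-fold higher number from compound 2 to compound 3 (1.20 log units; beyond the scatter). Both replacements of the aryl group by an alkoxy group at this position carried the number to the limit of the assay. Isopropoxy is the closest relative of ethoxy among the groups seen here, so compound 4 is expected to follow compound 3: the number should rise by at least a modest amount, and quite possibly past the reporting limit, with a 5.7-fold higher number from compound 1 to compound 4 (0.75 log units; beyond the scatter) as the expected step. The estimate for compound 4 is 12000 nM, within a range from 5000 nM to 40000 nM.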

Compound 4, half-maximal inhibitory concentration: 3150 nM
The estimate for compound 4 lay 3.8-fold (0.58 log units) above the measured number; measured number below the stated range.
By their numbers in this assay, from the lowest: compound 2; then compounds 1 and 4 (each within the scatter of the next). At a limit, above all of these: compound 3.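

In this assay, an alkoxy group on the aromatic carbon next to the ring nitrogen need not end the activity: isopropoxy in place of phenyl gives a 1.5-fold higher number from compound 1 to compound 4 (0.17 log units; within the scatter), while isopropoxy in place of 4-aminophenyl still gives a 5.0-fold higher number from compound 2 to compound 4 (0.70 log units; beyond the scatter). The loss seen with ethoxy therefore does not extend to every alkoxy group at this position, and the change that separates the two is small: methyl in place of hydrogen on the saturated chain carbon bound to the oxygen gives an at least 3.1-fold lower number from compound 3 to compound 4 (0.50 log units; beyond the scatter). Compound 3 is a limit and not a number, so that step gives only a bound on the difference: the limit of > 10000 nM in this assay, at which 1 of the 4 values shown sits.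

The compounds shown leave open whether the ethoxy result is an isolated drop or part of a trend along the alkoxy series, which a methoxy, a tert-butoxy or a cyclopropylmethoxy group at this position could begin to settle. They also leave open whether the gain seen with the amino group on the phenyl ring would persist with a hydroxyl, a carboxylic acid or a dimethylamino group in its place.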